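A Fused Ring Replaces the Amide Side Chain

A few compounds are considered here, and "the series" means these few. Any claim that something is new, unique, unknown or untested is made for them only; others in the source may bear on it.

In a functional assay on BaF3 cells (Mus musculus) for antiproliferative activity, read by CCK-8 assay and cell counting, with a stated time of 76 h (a higher number here means a weaker inhibitor, a lower number a stronger inhibitor), compound 3 (`COc1cc2nccc(Oc3ccc(Nc4nn(C)cc4C(=O)NCC4CCCO4)cc3)c2cc1C(N)=O`) gives > 10000 nM, which is a limit of the assay and not a number. Compound 1 (`COc1cc2nccc(Oc3ccc(Nc4nn(C)cc4C(=O)NCc4ccccc4)cc3)c2cc1C(N)=O`) gives > 10000 nM, also a limit. Compound 2 (`COc1cc2nccc(Oc3ccc(Nc4nn(C)cc4C(=O)NC4CCCCC4)cc3)c2cc1C(N)=O`) gives a true number, 4800 nM. Compound 4 (`COc1cc2nccc(Oc3ccc(Nc4nn(C)cc4C(=O)N4CCCC5CCCCC54)cc3)c2cc1C(N)=O`) changes the group on the carbonyl carbon: a group of 10 heavy atoms (9 carbon, 1 nitrogen; one six-membered non-aromatic ring of carbon only, one six-membered non-aromatic ring with 1 hetero atom) in place of a group of 7 heavy atoms (5 carbon, 1 nitrogen, 1 oxygen; one five-membered non-aromatic ring with 1 hetero atom), on a carbonyl carbon. For the measured compounds named here, two measured steps bear on this: an at least 2.0-fold lower number from compound 1 to compound 2 (0.31 log units; beyond the scatter) and an at least 2.0-fold higher number from compound 2 to compound 3 (0.31 log units; beyond the scatter). The entering group holds a six-membered non-aromatic ring of carbon only, as the cyclohexyl of compound 2 does, so compound 4 is expected to resemble compound 2 at 4800 nM. The expected change is modest and toward a lower number: an at least 1.6-fold lower number from compound 3 to compound 4 (0.22 log units; that floor lies within the scatter). For compound 4 the estimated value is 6000 nM, within an expected range of 2000 nM to 15000 nM.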

Compound 4, half-maximal inhibitory concentration: 4330 nM
Compound 4: the middle estimate sits 1.4-fold (0.14 log units) above what was measured, and the stated range covers the measured number.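

The entering group carries no hydrogen-bond donor, yet the result is a 1.1-fold lower number from compound 2 to compound 4 (0.04 log units; within the scatter), so on this carbonyl carbon the amide hydrogen is not needed to reach the level of compound 2. Against the other two compounds, the steps are an at least 2.3-fold lower number from compound 3 to compound 4 (0.36 log units; beyond the scatter) and an at least 2.3-fold lower number from compound 1 to compound 4 (0.36 log units; beyond the scatter), and both sizes are only floors: the limit of > 10000 nM in this assay, at which 2 of the 4 values shown sit.

On these data alone, whether the fused carbon ring contributes at all stays open, since plain piperidine on the same carbonyl carbon would be the direct comparison. As far as these compounds go, whether any group here can reach a much lower number also remains unknown.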